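Saturating the ester chain: compound 3 to compound 4

The source may report more compounds than this note shows. Statements on the series, on what has been measured and on what is new or still open speak of the compounds shown alone.

Working notes on the series. Compound 3 `COC(=O)/C=C/c1ccncc1-c1ccc2ccccc2c1` gives 40.6 nM in an assay on a protein complex for inhibition of CDK8/Cyclin C (Homo sapiens), with a stated time of 1 h (a higher number here means a weaker inhibitor, a lower number a stronger inhibitor), the second highest of three numbers. Compound 2 `O=C(CCc1ccncc1-c1ccc2ccccc2c1)N1CCOCC1` gives 45.5 nM, within the scatter of compound 3. Compound 1 `CNC(=O)/C=C/c1ccncc1-c1ccc2ccccc2c1` gives 12.4 nM and stands furthest off: a 3.3-fold higher number from compound 1 to compound 3 (0.52 log units; beyond the scatter). Compound 4 `COC(=O)CCc1ccncc1-c1ccc2ccccc2c1` differs from compound 3 by 2-(methoxycarbonyl)ethyl in place of 2-(methoxycarbonyl)ethenyl on an aromatic carbon. Going by the values given here, no measured step isolates this change; the single step measured concerns the group on the carbonyl carbon, not the chain. Compound 1 at 12.4 nM and compound 2 at 45.5 nM differ in two places at once, so they only hint at a somewhat higher number with the saturated chain. In this assay compound 4 is therefore expected near 65 nM, between 25 nM and 170 nM. That estimate means a 1.6-fold higher number from compound 3 to compound 4 (0.20 log units; within the scatter), expected to be modest.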

Compound 4, half-maximal inhibitory concentration: 259 nM
Compound 4: the middle estimate sits 4.0-fold (0.60 log units) below what was measured; measured number above the stated range.
By their numbers in this assay, from the lowest: compound 1; then compounds 3 and 2 (each within the scatter of the next); then compound 4.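

With 2-(methoxycarbonyl)ethyl in place of 2-(methoxycarbonyl)ethenyl, this assay shows a 6.4-fold higher number from compound 3 to compound 4 (0.80 log units; beyond the scatter), so the chain's double bond counts at this position, opposite the ring nitrogen. On the saturated chain the carbonyl group counts too: methoxy in place of morpholin-4-yl gives a 5.7-fold higher number from compound 2 to compound 4 (0.76 log units; beyond the scatter), and changing chain and carbonyl group together gives a 21-fold higher number from compound 1 to compound 4 (1.32 log units; beyond the scatter). No measurement shown explains the effect of saturation.

Still open, from the compounds shown here alone, is whether 2-(methylcarbamoyl)ethyl would show a similar loss on the amide side. Going by these compounds, how a carboxylic acid or a longer chain would fare at this position also remains open.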